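Chloro removed from compound 2: expected effect on growth inhibition

The source may report more compounds than this note shows. Statements on the series, on what has been measured and on what is new or still open speak of the compounds shown alone.

Of the compounds shown here, three sharing one core have been measured in a functional assay on HCC 2998 cells (Homo sapiens) for cytotoxicity, read by sulforhodamine B assay, with a stated time of 48 h; a lower number here means a stronger inhibitor of growth, a higher number a weaker inhibitor of growth. Compound 1 `ClCc1cccc(Cn2cnc3ncnc(Cl)c32)c1` gives 3230 nM. Compound 2 `ClCc1ccc(Cn2cnc3nc(Cl)nc(Cl)c32)cc1` gives 3800 nM. Compound 3 `Nc1nc(Cl)c2ncn(Cc3cccc(CCl)c3)c2n1` gives 4890 nM. In this assay compound 2 lies within the usual scatter of both compound 1 and compound 3, so the three numbers cannot be separated. Compound 4 `ClCc1ccc(Cn2cnc3ncnc(Cl)c32)cc1` is not yet measured. It differs from compound 2 by hydrogen in place of chloro on an aromatic carbon. Going by the values given here, no measured pair shows this change, so there is no basis for a step beyond the scatter in either direction; the expected step is small: a 1.1-fold lower number from compound 2 to compound 4 (0.02 log units; within the scatter). Compound 4 is estimated at 3600 nM in this assay because compound 2 gives 3800 nM. The range expected for compound 4 runs from 1500 nM to 9000 nM.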

Compound 4, concentration for total growth inhibition: 2880 nM
The estimate for compound 4 lay 1.3-fold (0.10 log units) above the measured number; the measured number falls inside the stated range.
By their numbers in this assay, from the lowest: compounds 4, 1, 2 and 3 (each within the scatter of the next).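

In this assay, going by these compounds alone, the first matched pair of the series gives a 1.3-fold lower number from compound 2 to compound 4 (0.12 log units; within the scatter) for hydrogen in place of chloro on an aromatic carbon between two ring nitrogen atoms. At this position, then, the chloro group can be lost with no change that can be told from the scatter. Nothing available explains this result. On these data alone, whether a methoxy or nitrile group on this carbon would read differently stays open. So does the effect of replacing the remaining chloro group in compound 4 with a methyl group.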